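Adding a Methoxy to a Pyrazolyl Chalcone's Aryl Ketone

A few compounds are considered here, and "the series" means these few. Any claim that something is new, unique, unknown or untested is made for them only; others in the source may bear on it.

Measured compounds:
- Compound 1 `COc1cc(-c2cc(/C=C/C(=O)c3ccc(N)cc3)[nH]n2)cc(OC)c1OC`: "not determined" (no result reported)
- Compound 2 `COc1ccc(C(=O)/C=C/c2cc(-c3cc(OC)c(OC)c(OC)c3)n[nH]2)cc1OC`: 2200 nM

In a functional assay on CAKI-1 cells (Homo sapiens) for inhibition, read by sulforhodamine B assay, with a stated time of 48 h (on this read-out lower numbers stand for stronger inhibition of growth and higher numbers for weaker inhibition of growth), compound 2 gives 2200 nM. Among the compounds with values here, this is the only number in hand; for compound 1 the entry in this assay is "not determined" (no result reported), so compound 2 cannot be ranked against anything. Compound 3 `COc1cc(C(=O)/C=C/c2cc(-c3cc(OC)c(OC)c(OC)c3)n[nH]2)cc(OC)c1OC` has not yet been measured. It differs from compound 2 by methoxy in place of hydrogen on an aromatic carbon, ortho to a methoxy group and meta to a methoxy group and to a large group.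

Within the data shown here, no step between measured compounds is available to calibrate this change, so the expectation rests on compound 2 alone. The added methoxy is estimated to leave growth inhibition close to that of compound 2, with a step of a 1.5-fold lower number from compound 2 to compound 3 (0.17 log units; within the scatter) that is expected to stay within the usual scatter. Compound 3 is therefore expected to give about 1500 nM, within a range from 500 nM to 5000 nM.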

Compound 3, concentration for 50% growth inhibition: 2580 nM
Compound 3: the middle estimate sits 1.7-fold (0.24 log units) below what was measured; measured number inside the range.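

In this assay the added methoxy gives a 1.2-fold higher number from compound 2 to compound 3 (0.07 log units; within the scatter) and thus no readable change in growth inhibition. Within the data shown here, this is the first comparison at this position: compound 2 alone could not show whether the aromatic carbon that is ortho to a methoxy group, and meta to a methoxy group and to a large group, would tolerate a methoxy in place of hydrogen, and here that swap leaves the read-out within the scatter. Nothing at hand explains this result, and no cause can be offered for it.

From the compounds shown here alone, whether a hydroxyl or a carboxylic acid in place of hydrogen on this same aromatic carbon would also stay within the scatter remains open. Going by these compounds, it is also open whether the same methoxy change would behave alike on another core, and a single step says nothing on that.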